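Adding a Second Hydroxy to a Weakly Cytotoxic Scaffold

A few compounds are considered here, and "the series" means these few. Any claim that something is new, unique, unknown or untested is made for them only; others in the source may bear on it.

Compound 2 `CC(C)NC(=N)c1ccc(-c2cc3cc(C(=N)NC(C)C)cc(O)c3o2)cc1` was tested in an ADME assay on L6 cells (Rattus norvegicus) for cytotoxicity (on this read-out higher numbers stand for weaker inhibition and lower numbers for stronger inhibition), and compound 2 gives only the limit > 185000 nM, so its true value is not known. Compound 1 `COc1cc(C(=N)NC(C)C)cc2cc(-c3ccc(C(=N)NC(C)C)cc3)oc12` likewise gives only the limit > 190000 nM. The step that the two limits leave unreadable from compound 1 to compound 2 therefore cannot be read. Compound 3 `CC(C)NC(=N)c1ccc(-c2cc3cc(C(=N)NC(C)C)cc(O)c3o2)c(O)c1` carries hydroxy in place of hydrogen on an aromatic carbon. Going by the values given here, no measured step shows what a hydroxy does here; the evidence consists of the limit of > 185000 nM in this assay, at which 1 of the 2 values shown sits, and (the limit of > 190000 nM in this assay, at which 1 of the 2 values shown sits). Compound 3 is expected to stay at a limit, with a step that the limit leaves unreadable from compound 2 to compound 3 estimated as no change beyond the scatter. Compound 3 is estimated at 200000 nM, ranging from 90000 nM to 450000 nM.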

Compound 3, half-maximal inhibitory concentration: > 179000 nM
Compound 3: only a limit was reported; the forecaster's own chance of this, stated with the estimate: 85%; the middle value lies beyond the limit too.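

Compound 3 also gives only a limit in this assay, so neither the step from compound 1 to compound 2 nor the step from compound 2 to compound 3 can be read. How strongly any of these compounds inhibits the cells, and what the added hydroxy does, stays open.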